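Swapping the Benzyl Group: From Compound 2 to Compound 3

The source may hold more compounds than are shown below. What is called first, only, known or untested is meant among the compounds shown, and "the series" means these compounds.

Compound 1 `O=c1ccoc2cc(OCc3cn(Cc4ccc(Cl)cc4Cl)nn3)ccc12`: > 100000 nM, a limit of the assay
Compound 2 `O=c1ccoc2cc(OCc3cn(Cc4ccc(F)cc4)nn3)ccc12`: > 100000 nM, a limit of the assay

In a functional assay on MDA-MB-231 cells (Homo sapiens) for cytotoxicity, read by MTT assay, with a stated time of 48 h (on this read-out higher numbers stand for weaker inhibition and lower numbers for stronger inhibition), compound 1 gives only the limit > 100000 nM. Compound 2 likewise gives only the limit > 100000 nM, so its standing on this read-out cannot be placed. For the measured compounds named here, the single measured step, a step that the two limits leave unreadable from compound 1 to compound 2, is therefore unreadable; (the limit of > 100000 nM in this assay, at which 2 of the 2 values shown sit). Compound 3 `O=c1ccoc2cc(OCc3cn(Cc4ccccc4Cl)nn3)ccc12` differs from compound 2 by 2-chlorophenyl in place of 4-fluorophenyl on a saturated chain carbon bound to an aromatic nitrogen. Going by the values given here, no measured step shows how this change acts, so neither size nor direction can be read. Compound 3 is expected to sit at about 150000 nM, within 50000 nM to 500000 nM. The expected step is a step that the limit leaves unreadable from compound 2 to compound 3.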

Compound 3, half-maximal inhibitory concentration: 15100 nM
Compound 3: the middle estimate sits 9.9-fold (1.00 log units) above what was measured, and the stated range ends above it.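

In this assay, replacing 4-fluorophenyl with 2-chlorophenyl brings an at least 6.6-fold lower number from compound 2 to compound 3 (0.82 log units; beyond the scatter), the first readable activity in this series. Hydrogen in place of chloro on an aromatic carbon also brings an at least 6.6-fold lower number from compound 1 to compound 3 (0.82 log units; beyond the scatter), so one chloro rather than two on this ring separates a measured value from a limit.

On these data alone, the true size of both steps stays open because the two starting compounds reach only a limit: the limit of > 100000 nM in this assay, at which 2 of the 3 values shown sit. As far as these compounds go, whether an amine or a methoxy group on the same ring would lower the number further also remains open.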